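A few compounds are considered here, and "the series" means these few. Any claim that something is new, unique, unknown or untested is made for them only; others in the source may bear on it.

In a functional assay on CCRF-CEM cells (Homo sapiens) for inhibition, read by sulforhodamine B assay, with a stated time of 48 h, tested at 10 uM (on this read-out lower numbers stand for a stronger effect and higher numbers for a weaker effect at the one concentration tested), compound 1 `COc1cc(Cl)cc(-c2nn(-c3cccc(NC(=O)Nc4ccc(Cl)c(Cl)c4)c3)cc2-c2ccncc2)c1` gives 5.73% and compound 2 `COc1cc(Cl)cc(-c2nn(-c3cccc(NC(=O)c4cccc(C(F)(F)F)c4)c3)cc2-c2ccncc2)c1` gives 42.3%, so compound 2 stands highest of the two numbers. Going by the values given here, the single measured step, a number 36.6 percentage points higher from compound 1 to compound 2 (beyond the scatter), concerns a different change and bears only loosely on the next one. Compound 3 `COc1cc(Cl)cc(-c2nn(-c3cccc(NC(=O)c4cc(C(F)(F)F)cc(C(F)(F)F)c4)c3)cc2-c2ccncc2)c1` differs from compound 2 by trifluoromethyl in place of hydrogen on an aromatic carbon. Nothing measured probes this kind of change, so for compound 3 a step in this assay no larger than the scatter, in either direction, is expected, a number 2.7 percentage points higher from compound 2 to compound 3 (within the scatter). Compound 3 is estimated at 45%, with a range from 20% to 75%.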

Compound 3, a percentage reported as activity, at one concentration (the size of the read-out at that concentration, not a potency): 57.1%
The estimate for compound 3 lay 12.1 percentage points below the measured number, within the range that was stated.
By their numbers in this assay, from the lowest: compound 1; then compound 2; then compound 3.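

In this assay, trifluoromethyl in place of hydrogen on this aromatic carbon, meta to a trifluoromethyl group, is not a neutral change: it gives a number 14.8 percentage points higher from compound 2 to compound 3 (beyond the scatter), a weaker effect at the one concentration tested. This carbon therefore responds to substitution, at least for this group. Nothing available accounts for the step.

On these data alone, whether an amine or a carboxylic acid on this carbon would weaken the effect, leave it unchanged or strengthen it remains open. Also open, as far as these compounds go, is whether the same addition would shift the number similarly in compound 1.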